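Amide substitution on the piperidine carbonyl of the sulfonamide series

A few compounds are considered here, and "the series" means these few. Any claim that something is new, unique, unknown or untested is made for them only; others in the source may bear on it.

Three compounds of the series have numbers in a functional assay on BXPC-3 cells (Homo sapiens) for inhibition, read by MTT assay, with a stated time of 7 days (on this read-out lower numbers stand for stronger inhibition and higher numbers for weaker inhibition), so far. Compound 1 `CCOC(=O)[C@@H]1CCCN(C(=O)c2ccc(S(=O)(=O)N(CC)CC)cc2)C1` reaches only the limit of the assay, giving > 10000 nM in this assay; the limit of > 10000 nM in this assay, at which 1 of the 3 values shown sits, applies to it. Compound 2 `CCN(CC)C(=O)[C@@H]1CCCN(S(=O)(=O)c2ccc(S(=O)(=O)N(CC)CC)cc2)C1` gives 10500 nM in this assay, the lower of the two numbers that are not limits. Compound 3 `CCOC(=O)[C@@H]1CCC[C@@H](S(=O)(=O)c2ccc(S(=O)(=O)N(CC)CC)cc2)C1` gives 18500 nM in this assay, and the gap between compound 2 and compound 3 lies within the scatter, so the two cannot be told apart.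

Compound 4 `CCN(CC)S(=O)(=O)c1ccc(S(=O)(=O)N2CCC[C@@H](C(=O)NC)C2)cc1` has not yet been measured in this assay. It differs from compound 2 in one place: methylamino in place of diethylamino on a carbonyl carbon. Within the data shown here, no measured pair shows this kind of change, so no step size can be read from the data.

The step from compound 2 to compound 4 is expected to be a 1.1-fold higher number from compound 2 to compound 4 (0.06 log units; within the scatter), that is, no change beyond the scatter. Compound 4 is expected to give about 12000 nM in this assay, with a range from 4000 nM to 40000 nM.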

Compound 4, half-maximal inhibitory concentration: 13800 nM
Compound 4: middle estimate off by 1.2-fold (0.06 log units), on the low side, and the stated range covers the measured number.
By their numbers in this assay, from the lowest: compounds 2, 4 and 3 (each within the scatter of the next).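

In this assay, among these compounds, the first measured pair at this carbonyl carbon gives a 1.3-fold higher number from compound 2 to compound 4 (0.12 log units; within the scatter): replacing diethylamino with the smaller methylamino, which carries a hydrogen-bond donor that diethylamino lacks, leaves the number within the scatter. On this one pair, the amine part of the amide shows no readable effect on the number, and a single pair cannot support a wider trend. Compound 1 stands at a limit of the assay, not at a number: the limit of > 10000 nM in this assay, at which 1 of the 4 values shown sits.

Going by these compounds, it remains open whether any group on this carbonyl carbon separates from these two amides; a carboxylic acid, a primary amide or a morpholine amide would test this. On these data alone, it is also open whether the same flat step would hold on a core that gives much lower numbers.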